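The source may report more compounds than this note shows. Statements on the series, on what has been measured and on what is new or still open speak of the compounds shown alone.

Compound 1 `c1cc(C2CCCCC2)ccc1NC1=NCCO1` gives 12800 nM
Compound 2 `c1cc(NC2=NCCO2)cc(OC2CCCCC2)c1` gives 4400 nM
Compound 3 `O=C(CCl)NC(=O)Nc1ccc(-c2ccccc2)cc1` gives 2300 nM

In a functional assay on HT-29 cells (Homo sapiens) for inhibition, read by sulforhodamine B assay, with a stated time of 48 h (on this read-out higher numbers stand for weaker inhibition of growth and lower numbers for stronger inhibition of growth), compound 3 (2300 nM) cannot be told apart from compound 2 (4400 nM), as the two lie within the usual scatter, whereas compound 1 (12800 nM) stands higher, beyond the scatter.

The next compound to be measured is compound 4 `CC(C)(C)c1ccc(NC(=O)NC(=O)CCl)cc1`, which differs from compound 3 in one place. The change is tert-butyl in place of phenyl on an aromatic carbon in all, tert-butyl in place of phenyl on an aromatic carbon, para to a group of 8 heavy atoms. For the measured compounds named here, no measured pair shows a change of this kind, so the data give no direct size for it. In this assay a small move towards a higher number is expected, probably none beyond the scatter, which keeps the expectation close to compound 3 (2300 nM) as the only measured reference. The expected size is a 1.3-fold higher number from compound 3 to compound 4 (0.12 log units; within the scatter) on this estimate. For compound 4 the estimated value is 3000 nM with an expected range from 1200 nM to 7500 nM in this measurement.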

Compound 4, concentration for 50% growth inhibition: 3300 nM
Compound 4: middle estimate off by 1.1-fold (0.04 log units), on the low side; the measured number falls inside the stated range.
By their numbers in this assay, from the lowest: compounds 3, 4 and 2 (each within the scatter of the next); then compound 1.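

In this assay, tert-butyl in place of phenyl on an aromatic carbon, para to a group of 8 heavy atoms, gives a 1.4-fold higher number from compound 3 to compound 4 (0.16 log units; within the scatter), so the two compounds cannot be told apart. This first step at the position shows that the six-membered aromatic ring of phenyl is not required there for growth inhibition in this assay, as tert-butyl has no ring and fewer heavy atoms yet keeps the read-out within the scatter. Nothing available gives a reason for this outcome.

Going by these compounds, what remains open is whether the position accepts any group, since an amine, a carboxylic acid or a longer alkyl chain could behave differently there. This single step also cannot show whether the same swap would hold on another core.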